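Carboxy for trihydroxybenzyl on the shared quinolone core

The compounds below may be only part of what the source reports. "The series", "measured", "known", "first", "only" and "open" are said of these compounds alone.

Three compounds of the series have numbers in a functional assay on P388 cells (Mus musculus) for cytotoxicity; on this read-out lower numbers stand for stronger inhibition and higher numbers for weaker inhibition. Compound 1 `COc1ccccc1Cc1cn(C2CC2)c2c(F)c(-c3cc(C)nc(C)c3)c(F)cc2c1=O` gives 37000 nM. Compound 2 `Cc1cc(-c2c(F)cc3c(=O)c(Cc4cc(O)ccc4O)cn(C4CC4)c3c2F)cc(C)n1` gives 360 nM, and compound 3 `Cc1cc(-c2c(F)cc3c(=O)c(Cc4c(O)cc(O)cc4O)cn(C4CC4)c3c2F)cc(C)n1` gives 470 nM. Compound 3 thus stands second highest of the three; it is closest to compound 2, with a 1.3-fold higher number from compound 2 to compound 3 (0.12 log units; within the scatter) separating them, and furthest from compound 1, from which a 79-fold lower number from compound 1 to compound 3 (1.90 log units; beyond the scatter) leads down to it. The parallel step a 100-fold lower number from compound 1 to compound 2 (2.01 log units; beyond the scatter) is of the same size.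

Compound 4 `Cc1cc(-c2c(F)cc3c(=O)c(C(=O)O)cn(C4CC4)c3c2F)cc(C)n1` is the next compound. Its change from compound 3 is carboxy in place of 2,4,6-trihydroxybenzyl on an aromatic carbon, on an aromatic carbon of a six-membered aromatic ring with 1 nitrogen, two atoms from the ring nitrogen. Within the data shown here, no measured step touches this position: the two large steps and the one small step all exchange one substituted phenyl for another on the saturated chain carbon, and none removes the benzyl altogether or brings in a carboxy. They therefore give no direct guide, and the expectation rests on the loss of the group that carried the gain seen in compound 2 and compound 3 over compound 1.

The estimate for compound 4 in this assay is 6000 nM, within 600 nM to 60000 nM, which means an expected step of a 13-fold higher number from compound 3 to compound 4 (1.11 log units; beyond the scatter) toward weaker inhibition, with wide uncertainty.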

Compound 4, half-maximal inhibitory concentration: 29000 nM
The estimate for compound 4 lay 4.8-fold (0.68 log units) below the measured number; the measured number falls inside the stated range.
By their numbers in this assay, from the lowest: compounds 2 and 3 (each within the scatter of the next); then compounds 4 and 1 (each within the scatter of the next).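

In this assay, among these compounds, carboxy in place of 2,4,6-trihydroxybenzyl gives a 62-fold higher number from compound 3 to compound 4 (1.79 log units; beyond the scatter) and carboxy in place of 2,5-dihydroxybenzyl gives an 81-fold higher number from compound 2 to compound 4 (1.91 log units; beyond the scatter), so this aromatic carbon, two atoms from the ring nitrogen, responds strongly when the whole benzyl group is exchanged, something the earlier steps on the saturated chain carbon could not show. Carboxy in place of 2-methoxybenzyl gives a 1.3-fold lower number from compound 1 to compound 4 (0.11 log units; within the scatter), which places compound 1 and compound 4 together and shows that, among these four compounds, the lower numbers belong only to the two benzyl groups bearing free hydroxy groups, not to every benzyl group at this position. No measurement shown here gives a reason for these steps.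

On these data alone, how a benzyl group with a single hydroxy group, a primary amide or an aminomethyl group would stand at this position remains open, and so does whether an unsubstituted benzyl group would group with compound 1 or with compound 2 and compound 3. As far as these compounds go, the cyclopropyl group and the rest of the shared core are the same in all four compounds, so whether these steps hold with another group on the ring nitrogen, such as ethyl, is also open.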